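The source may hold more compounds than are shown below. What is called first, only, known or untested is meant among the compounds shown, and "the series" means these compounds.

Measured compounds: compound 1 `NS(=O)(=O)C1CCN(c2ncc(C(=O)Nc3nc(-c4cccc(C(F)(F)F)c4F)cs3)cc2Cl)CC1` gives 4.86 in a physicochemical assay for lipophilicity; on this read-out lower numbers stand for lower lipophilicity and higher numbers for higher lipophilicity; compound 2 `C[C@H]1CN(c2ncc(C(=O)Nc3nc(-c4cccc(C(F)(F)F)c4F)cs3)cc2Cl)CC1C(=O)O` gives 2.79 in this assay; compound 3 `O=C(Nc1nc(-c2cccc(C(F)(F)F)c2F)cs1)c1cnc(N2CCCC(C(=O)O)C2)c(Cl)c1` gives 2.94 in this assay.

Among these three numbers compound 3 stands second highest. Its nearest neighbour is compound 2, and the step of a number 0.15 log units higher from compound 2 to compound 3 (within the scatter) lies within the scatter, so the two cannot be told apart. The step of a number 1.92 log units lower from compound 1 to compound 3 (beyond the scatter) is large, as is the parallel step a number 2.07 log units lower from compound 1 to compound 2 (beyond the scatter). Compound 4 `O=C(Nc1nc(-c2cccc(C(F)(F)F)c2F)cs1)c1cnc(N2CCC(c3nn[nH]n3)CC2)c(Cl)c1` is not yet measured. Its change from compound 3 is 4-(2H-tetrazol-5-yl)piperidin-1-yl in place of 3-carboxypiperidin-1-yl on an aromatic carbon. Within the data shown here, no measured step here swaps a carboxy group for a tetrazolyl group; the large steps both concern the sulfamoyl group, and the one small step concerns the ring and its methyl group. The expectation for compound 4 therefore rests on the change itself, and a modest step, a number 0.26 log units higher from compound 3 to compound 4 (within the scatter), is estimated, which may not exceed the scatter. Compound 4 is expected to give 3.2 in this assay, with a range from 2.4 to 4.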

Compound 4, distribution coefficient: 3.24
Compound 4: the middle estimate sits 0.04 log units below what was measured; the measured number falls inside the stated range.
By their numbers in this assay, from the lowest: compounds 2, 3 and 4 (each within the scatter of the next, the first and the last beyond it); then compound 1.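

In this assay a ring with a tetrazole can stand at this place, on an aromatic carbon next to the ring nitrogen, without a clear shift from the 3-carboxypiperidin-1-yl compound (a number 0.30 log units higher from compound 3 to compound 4 (within the scatter)). The step from the 3-carboxy-4-methylpyrrolidin-1-yl compound is the only one among these three groups to pass the scatter, and it stays modest (a number 0.45 log units higher from compound 2 to compound 4 (beyond the scatter)). The cleanest comparison keeps the piperidine and its 4-position, and swapping sulfamoyl for 2H-tetrazol-5-yl there gives a large step (a number 1.62 log units lower from compound 1 to compound 4 (beyond the scatter)), which puts compound 4 with the carboxy compounds, well apart from compound 1.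

No measurement shown explains these steps. On these data alone, compound 3 and compound 4 differ in both group and ring position, so a 4-carboxypiperidin-1-yl group would be needed to separate the two, and how an amine on the same ring would read remains open.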